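Furan-2-yl in Place of 3-Chlorophenyl: Expected Cytotoxicity

The source may hold more compounds than are shown below. What is called first, only, known or untested is meant among the compounds shown, and "the series" means these compounds.

Compound 1, `COc1nc2ccccc2cc1/C=C/c1noc(-c2ccccc2C)n1`, gives in an ADME assay on HepG2 cells (Homo sapiens) for cytotoxicity, read by sulforhodamine B assay, with a stated time of 48 h (on this read-out lower numbers stand for higher toxicity in this test and higher numbers for lower toxicity in this test), only a limit of the assay, > 230000 nM.
Compound 2, `COc1nc2ccccc2cc1/C=C/c1noc(-c2cccc(C)c2)n1`, gives in this assay only a limit, > 230000 nM.
Compound 3, `COc1nc2ccccc2cc1/C=C/c1noc(-c2cccc(Cl)c2)n1`, gives in this assay only a limit, > 220000 nM.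

Compound 3 therefore stands at a limit, like its two neighbours, so that a step that the two limits leave unreadable from compound 1 to compound 2, a step that the two limits leave unreadable from compound 1 to compound 3 and a step that the two limits leave unreadable from compound 2 to compound 3 cannot be sized; the only footing is the limit of > 220000 nM in this assay, at which 1 of the 3 values shown sits, and (the limit of > 230000 nM in this assay, at which 2 of the 3 values shown sit). Compound 4, `COc1nc2ccccc2cc1/C=C/c1noc(-c2ccco2)n1`, arises through (furan-2-yl in place of 3-chlorophenyl on an aromatic carbon). Among the compounds with values here, no measured step reads the effect of such a swap, so compound 4 is expected to show a step that the limit leaves unreadable from compound 3 to compound 4, which is to say none beyond the scatter. Compound 4 is accordingly estimated at 230000 nM in this assay, within 90000 nM to 600000 nM.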

Compound 4, half-maximal cytotoxic concentration: > 250000 nM
Compound 4: only a limit was reported (the forecaster's own chance of this, stated with the estimate: 80%); middle value at least 1.0-fold (0.03 log units) from the limit.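

Compound 4 gives only a limit of the assay, so its steps from compound 1, compound 2 and compound 3 cannot be read. The compounds shown leave open what concentration of any of them would prove cytotoxic in this assay, and whether furan-2-yl would differ there from the phenyl groups.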